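Chloro for methyl on the central ring, amide series

This account rests on a few compounds, and the source may have more. Where it says the series, first, only, none or still open, it means among the compounds named here.

Two compounds of this series carry numbers in a functional assay on HepG2 cells (Homo sapiens) for cytotoxicity, read by MTT assay, with a stated time of 72 h; on this read-out higher numbers stand for weaker inhibition and lower numbers for stronger inhibition. Compound 1 `O=C(Nc1ccc(Cl)c(C(=O)Nc2ccc(-c3ncc[nH]3)nc2)c1)c1ccc(Cl)c(Cl)c1` gives 15200 nM in this assay. Compound 2 `Cc1ccc(NC(=O)c2ccc(Cl)c(C(F)(F)F)c2)cc1C(=O)Nc1ccc(-c2ncc[nH]2)nc1` gives 6170 nM in this assay, the lower of the two numbers; its nearest neighbour is compound 1, and the separation between them lies beyond the scatter. Within the data shown here, no pair of measured compounds differs in one place only, so the two values show just that compound 1 and compound 2 sit apart, without a single change to tie that gap to.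

Compound 3 `O=C(Nc1ccc(Cl)c(C(=O)Nc2ccc(-c3ncc[nH]3)nc2)c1)c1ccc(Cl)c(C(F)(F)F)c1` remains to be measured in this assay. It differs from compound 2 by chloro in place of methyl on an aromatic carbon. Among the measured compounds shown here, compound 1 shares this chloro with compound 3 but differs elsewhere as well, so no direct step is available for it. The change is small in what it counts, and the step is expected to be small: a 1.3-fold higher number from compound 2 to compound 3 (0.11 log units; within the scatter), most likely within the scatter, with a slightly weaker outcome somewhat more plausible than a stronger one. Compound 3 is estimated at 8000 nM, with a range from 3000 nM to 22000 nM.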

Compound 3, half-maximal inhibitory concentration: 13800 nM
Compound 3: the middle estimate sits 1.7-fold (0.24 log units) below what was measured; the measured number falls inside the stated range.
By their numbers in this assay, from the lowest: compound 2; then compounds 3 and 1 (each within the scatter of the next).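

Methyl on this aromatic carbon, ortho to a large group and para to a large group, now has a direct reading in this assay: chloro in its place gives a 2.2-fold higher number from compound 2 to compound 3 (0.35 log units; beyond the scatter) and so counts as a modest loss, beyond the scatter, in a series whose values all lie at the weak end of those shown. The other change, trifluoromethyl in place of chloro on an aromatic carbon, gives a 1.1-fold lower number from compound 1 to compound 3 (0.04 log units; within the scatter) and stays within the scatter, so this read-out does not tell those two groups apart in the chloro-bearing compounds. Among these compounds, of the two single changes now read, only the one at the methyl position lies beyond the scatter, which gives the earlier unassigned separation a first place to point to.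

From the compounds shown here alone, the methyl to chloro step rests on one pair, so its size with other groups elsewhere on the molecule stays open, as does the reading of hydrogen, a methoxy group or an amine on this aromatic carbon. No measurement on hand offers a reason for either step.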